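Hydrogen in Place of Chloro: Expected Growth Inhibition

The source may report more compounds than this note shows. Statements on the series, on what has been measured and on what is new or still open speak of the compounds shown alone.

Measured compounds:
Compound 1, `COc1ccc(OC)c(/C=C/c2nnc(Nc3ccc(Cl)cc3)o2)c1`, gives 5230 nM in a functional assay on MDA-MB-231 cells (Homo sapiens) for antiproliferative activity, read by sulforhodamine B assay, with a stated time of 48 h; a higher number here means a weaker inhibitor of growth, a lower number a stronger inhibitor of growth.
Compound 2, `COc1ccc(OC)c(/C=C/C(=O)N/N=C/c2ccc(Cl)cc2)c1`, gives 1370 nM in this assay.

Compound 2 has the lowest number of the two, and compound 1 stands beyond the scatter above it. Compound 3, `COc1ccc(OC)c(/C=C/C(=O)N/N=C/c2ccccc2)c1`, differs from compound 2 by hydrogen in place of chloro on an aromatic carbon. Within the data shown here, no measured pair shows this change, so its effect is unknown here; a small step in this assay toward a higher number, or none beyond the scatter, is expected. Compound 3 is expected to give 2200 nM, within 800 nM to 6500 nM. The expected step is a 1.6-fold higher number from compound 2 to compound 3 (0.21 log units; within the scatter).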

Compound 3, concentration for 50% growth inhibition: 7240 nM
Estimate against measurement, compound 3: 3.3-fold (0.52 log units) below, outside the stated range (above it).
By their numbers in this assay, from the lowest: compound 2; then compounds 1 and 3 (each within the scatter of the next).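

On this aromatic carbon, para to a large group, the chloro counts for much in this assay: going from 4-chlorophenyl to phenyl gives a 5.3-fold higher number from compound 2 to compound 3 (0.72 log units; beyond the scatter), the first measured view of this change. Losing this single atom weakens growth inhibition beyond the scatter. No available evidence explains why the chloro matters here.

From the compounds shown here alone, whether a bromo, an amine or a carboxylic acid at this position would match the chloro, or even improve on it, remains open. So does whether the same change would act alike on the core of compound 1.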